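Chain extension on the shared core, toward compound 4

A few compounds are considered here, and "the series" means these few. Any claim that something is new, unique, unknown or untested is made for them only; others in the source may bear on it.

The series shares the core of compound 1 `CCCCCc1cc2ccccc2nc1-c1cc(-c2ccccc2)no1`, which in a functional assay on PC-3 cells (Homo sapiens) for inhibition, read by MTT assay, with a stated time of 24 h (a higher number here means a weaker inhibitor, a lower number a stronger inhibitor), gives only a limit of the assay, > 100000 nM. Compound 2 `CCc1cc2ccccc2nc1-c1cc(-c2ccc(C)cc2)no1` also reaches only a limit in this assay, > 100000 nM. Compound 3 `CCCCc1cc2ccccc2nc1-c1cc(-c2ccc(C)cc2)no1` stands at a limit in this assay as well, > 100000 nM. For the measured compounds named here, the one step within the measured set, a step that the two limits leave unreadable from compound 2 to compound 3, is left unreadable by the two limits. All three values sit at the same limit, (the limit of > 100000 nM in this assay, at which 3 of the 3 values shown sit), so no size or direction can be read for any change on the chain. Compound 4 `CCCCCc1cc2ccccc2nc1-c1cc(-c2ccc(C)cc2)no1` differs from compound 3 by methyl in place of hydrogen on a saturated chain carbon, four bonds along the chain from an aromatic carbon; methyl in place of hydrogen on a saturated chain carbon, four bonds along the chain from an aromatic carbon. Going by the values given here, the only measured step on this chain gives no size, so no shift beyond the scatter can be read from it. The step expected in this assay is estimated as a step that the limit leaves unreadable from compound 3 to compound 4. Compound 4 is therefore expected to give about 150000 nM in this assay, within 50000 nM to 500000 nM, most likely reported once more as a limit.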

Compound 4, half-maximal inhibitory concentration: > 100000 nM
Compound 4: no number, only a limit; the forecaster's own chance of this, stated with the estimate: 85%; the middle value is on the limit's open side.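

Compound 4 stands at a limit in this assay, as do compound 1, compound 2 and compound 3, so none of the new steps to compound 4 can be read: the limit of > 100000 nM in this assay, at which 4 of the 4 values shown sit.

The compounds shown leave open whether any chain on the shared core has an effect in this assay.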